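The compounds below may be only part of what the source reports. "The series", "measured", "known", "first", "only" and "open" are said of these compounds alone.

Measured so far:
compound 1, `CO[C@@H]1[C@@H](OC)[C@H](Cc2ccccc2)O[C@@H]2CO[C@@H](c3ccccc3)O[C@@H]12`: 20 ug/mL
compound 2, `CO[C@@H]1[C@@H](OC)[C@H](c2ccccc2)O[C@@H]2CO[C@@H](C3CCCCC3)O[C@@H]12`: 20 ug/mL

Both numbers come from a functional assay on HEL cells (Homo sapiens) for cytotoxicity; a lower number here means that less compound is tolerated, a higher number that more compound is tolerated. In this assay compound 1 gives 20 ug/mL and compound 2 gives 20 ug/mL. Compound 2 stands level with compound 1 at the digits shown; compound 1 is its nearest neighbour in the set, and the gap is within the scatter of repeated measurements. Within the data shown here, no pair of measured compounds differs in only one place, so the set gives no single-change step to lean on. Among the measured compounds shown here, compound 1 and compound 2 differ in two places on the shared core and still return the same value, so within this set of two the read-out looks insensitive to such changes; no compound goes against this, but the set is small.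

Compound 3, `CO[C@@H]1[C@@H](OC)[C@H](c2ccccc2)O[C@@H]2CO[C@@H](c3ccc4ccccc4c3)O[C@@H]12`, has not been measured. It differs from compound 2 in one place: naphthalen-2-yl in place of cyclohexyl on a saturated ring carbon. For the measured compounds named here, with no measured single-change step to draw on and two members sitting at one value, the step from compound 2 to compound 3 is expected to be small or none beyond the scatter, in either direction, which is what no change at the digits printed from compound 2 to compound 3 (within the scatter) expresses. For compound 3 the estimated value is 20 ug/mL, with an expected range of 10 ug/mL to 40 ug/mL.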

Compound 3, minimum cytotoxic concentration: >= 16 ug/mL
Compound 3 gave a limit, no number; the forecaster's own chance of this, stated with the estimate: 15%; the middle value does not contradict the limit.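

In this assay compound 3 gives >= 16 ug/mL, which is a limit and not a number. Among these compounds, no step from compound 2 to compound 3 can be read from it. The compounds shown leave open whether naphthalen-2-yl in place of cyclohexyl on a saturated ring carbon shifts this read-out at all, in either direction.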